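The compounds below may be only part of what the source reports. "The series", "measured", "known", "first", "only" and "open" are said of these compounds alone.

Working notes on the shared core of compound 1 `CN(C)CCn1cnnc1-c1cc(Oc2ccc(NC(=O)N/N=C/c3ccc(O)c(F)c3)cc2F)ccn1` in a functional assay on U-87MG ATCC cells (Homo sapiens) for cytotoxicity, read by MTT assay, with a stated time of 72 h; on this read-out lower numbers stand for stronger inhibition and higher numbers for weaker inhibition. Compound 1 reaches only the limit of the assay, giving > 100000 nM. Compound 2 `CN(C)CCn1cnnc1-c1cc(Oc2ccc(NC(=O)N/N=C/c3cc(Br)c(O)c(Br)c3)cc2F)ccn1` likewise reaches only the limit, giving > 100000 nM. Between them the step is a step that the two limits leave unreadable from compound 1 to compound 2; both sit at the limit of > 100000 nM in this assay, at which 2 of the 3 values shown sit. Among the compounds with values here, compound 3 `COc1ccc(/C=N/NC(=O)Nc2ccc(Oc3ccnc(-c4nncn4CCN(C)C)c3)c(F)c2)c(OC)c1` is the only one with a read number: in this assay compound 3 gives 12600 nM. That yields an at least 7.9-fold lower number from compound 1 to compound 3 (0.89 log units; beyond the scatter) and an at least 7.9-fold lower number from compound 2 to compound 3 (0.89 log units; beyond the scatter), the two readable steps in the set, and both point the same way: the methoxy-bearing ring gives a number where the hydroxyl-bearing rings give none.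

Compound 4 `COc1cc(/C=N/NC(=O)Nc2ccc(Oc3ccnc(-c4nncn4CCN(C)C)c3)c(F)c2)cc(OC)c1OC` is not yet measured. Its change from compound 1 is 3,4,5-trimethoxyphenyl in place of 3-fluoro-4-hydroxyphenyl on a carbon with a double bond to nitrogen. Within the data shown here, the steps that bear on it are the two into compound 3, each at least modest and beyond the scatter, and 3,4,5-trimethoxyphenyl carries methoxy groups and no hydroxyl, as 2,4-dimethoxyphenyl does. Compound 4 is therefore expected to show an at least 5.0-fold lower number from compound 1 to compound 4 (0.69 log units; beyond the scatter) in this assay, a step of the same kind as an at least 7.9-fold lower number from compound 1 to compound 3 (0.89 log units; beyond the scatter). The estimate for compound 4 is 20000 nM, between 5000 nM and 100000 nM, with a fair chance that only a limit is again reported.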

Compound 4, half-maximal inhibitory concentration: 22500 nM
Compound 4: middle estimate off by 1.1-fold (0.05 log units), on the low side; the measured number falls inside the stated range.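

In this assay, within the data shown here, 3,4,5-trimethoxyphenyl on a carbon with a double bond to nitrogen gives an at least 4.4-fold lower number from compound 1 to compound 4 (0.64 log units; beyond the scatter) and an at least 4.4-fold lower number from compound 2 to compound 4 (0.64 log units; beyond the scatter), so compound 3 is no longer the only compound with a read number, and a second ring with methoxy groups and no hydroxyl gives one too. The step between the two methoxy-bearing rings is a 1.8-fold higher number from compound 3 to compound 4 (0.25 log units; within the scatter), so at this position 3,4,5-trimethoxyphenyl and 2,4-dimethoxyphenyl read as alike, despite their different number and placing of methoxy groups. Across the four compounds the split now follows the ring, with no compound going against it, and the two hydroxyl-bearing compounds, compound 1 and compound 2, remain at a limit rather than a number: the limit of > 100000 nM in this assay, at which 2 of the 4 values shown sit.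

The compounds shown do not separate the presence of methoxy groups from the absence of a hydroxyl, and a ring carrying a hydroxyl and a methoxy group together would test that directly. Going by these compounds, it also remains open whether an unsubstituted phenyl ring, or a ring bearing an amine or a carboxylic acid, would give a read number at this position.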